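The source may hold more compounds than are shown below. What is called first, only, known or untested is meant among the compounds shown, and "the series" means these compounds.

Measured so far in a functional assay on MCF7 cells (Homo sapiens) for inhibition, read by MTT assay, with a stated time of 3 days; a lower number here means a stronger inhibitor, a higher number a weaker inhibitor:
- compound 1 `CC[C@H](C)[C@H](NCC(=O)NNC(=O)COc1ccc(-c2nc3ccccc3s2)cc1OC)C(=O)O`: 1710 nM
- compound 2 `COc1cc(-c2nc3ccccc3s2)ccc1OCC(=O)NNC(=O)CN[C@@H](CS)C(=O)O`: 1230 nM
- compound 3 `COc1cc(-c2nc3ccccc3s2)ccc1OCC(=O)NNC(=O)CN(C(C)=O)[C@@H](CS)C(=O)O`: 1750 nM

In this assay, compound 3 at 1750 nM cannot be separated from the other two compounds: a 1.0-fold higher number from compound 1 to compound 3 (0.01 log units; within the scatter), and a 1.4-fold higher number from compound 2 to compound 3 (0.15 log units; within the scatter).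

The next structure is compound 4 `COc1cc(-c2nc3ccccc3s2)ccc1OCC(=O)NNC(=O)CN[C@@H](CS(=O)(=O)O)C(=O)O`, and the change is (1-carboxy-2-sulfoethyl)amino in place of acetyl(1-carboxy-2-sulfanylethyl)amino on a saturated chain carbon bound to a carbonyl carbon. In words, (1-carboxy-2-sulfoethyl)amino stands in place of acetyl(1-carboxy-2-sulfanylethyl)amino on a saturated chain carbon bound to a carbonyl carbon.

Within the data shown here, two measured steps bear on this change. Acetyl in place of hydrogen on the amine nitrogen gave a 1.4-fold higher number from compound 2 to compound 3 (0.15 log units; within the scatter), and this change removes that acetyl. Sulfanylmethyl in place of sec-butyl gave a 1.4-fold lower number from compound 1 to compound 2 (0.14 log units; within the scatter), the only measured change at that side chain. Both steps lie within the scatter, so neither points to a direction. Among the measured compounds shown here, no measured compound carries a sulfo group, which leaves that part of the change without a direct precedent.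

The expected step, a 1.0-fold lower number from compound 3 to compound 4 (0.01 log units; within the scatter), is none beyond the scatter. The estimate for compound 4 is 1700 nM, with an expected range from 750 nM to 4500 nM, kept wide for the untested sulfo group.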

Compound 4, half-maximal inhibitory concentration: 1870 nM
Compound 4: the middle estimate sits 1.1-fold (0.04 log units) below what was measured; the measured number falls inside the stated range.
By their numbers in this assay, from the lowest: compounds 2, 1, 3 and 4 (each within the scatter of the next).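

In this assay, the sulfo group now has a direct reading at this side chain: sulfo in place of sulfanyl gives a 1.5-fold higher number from compound 2 to compound 4 (0.18 log units; within the scatter), and sulfomethyl in place of sec-butyl gives a 1.1-fold higher number from compound 1 to compound 4 (0.04 log units; within the scatter). The full change, which also removes the acetyl from the amine nitrogen, gives a 1.1-fold higher number from compound 3 to compound 4 (0.03 log units; within the scatter), so this compound pair cannot be separated either. Sec-butyl, sulfanylmethyl and sulfomethyl on the saturated chain carbon bound to an amine nitrogen and a carbonyl carbon therefore remain within the scatter of one another in this series, and no accompanying data offer an explanation for that result.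

The compounds shown leave open whether a sulfo group combined with an acetyl on the amine nitrogen would read differently from compound 4, since the two features appear here only as a single combined change. They also leave open whether an amine or a longer alkyl chain at this side chain, or a methyl ester in place of the carboxylic acid, would move the number beyond the scatter.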